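Methyl for methoxy on a quinoline thiosemicarbazone

The source may report more compounds than this note shows. Statements on the series, on what has been measured and on what is new or still open speak of the compounds shown alone.

Measured compounds:
compound 1, `COc1cccc(NC(=S)N/N=C/c2ccc3ccccc3n2)c1`: 79400 nM
compound 2, `Cc1ccc(NC(=O)N/N=C/c2ccc3ccccc3n2)cc1`: > 100000 nM
compound 3, `CN(C)C(=S)N/N=C/c1ccc2ccccc2n1`: 30 nM

In a functional assay on SGC-7901 cells (Homo sapiens) for antiproliferative activity, read by sulforhodamine B assay, with a stated time of 72 h (a lower number here means a stronger inhibitor, a higher number a weaker inhibitor), compound 1 gives 79400 nM, the highest of the two numbers recorded. The nearest number belongs to compound 3, which in this assay gives 30 nM, a gap far beyond the usual scatter. Compound 2 is known only as a limit of this assay, > 100000 nM, and not as a number (the limit of > 100000 nM in this assay, at which 1 of the 3 values shown sits).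

Compound 4, `Cc1cccc(NC(=S)N/N=C/c2ccc3ccccc3n2)c1`, has not yet been measured in this assay. It differs from compound 1 in one place: methyl in place of methoxy on an aromatic carbon. Within the data shown here, no step between measured compounds matches this change, so the expectation rests on compound 1 alone. Such a small exchange on the aryl ring is expected to leave the number close to that of compound 1, with no step beyond the scatter in either direction; the expected step is a 1.0-fold higher number from compound 1 to compound 4 (0.00 log units; within the scatter). Compound 4 is therefore estimated at 80000 nM, within a range from 25000 nM to 250000 nM.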

Compound 4, half-maximal inhibitory concentration: > 100000 nM
Compound 4: only a limit was reported; the forecaster's own chance of this, stated with the estimate: 35%; middle value at least 1.2-fold (0.09 log units) away from the limit.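

In this assay compound 4 gives > 100000 nM, which is a limit of the assay and not a number. Methyl in place of methoxy gives an at least 1.2-fold higher number from compound 1 to compound 4 (0.10 log units; that floor lies within the scatter), so this is the first step read on the aryl ring, and only its floor is known, which lies within the scatter. The result shows that with 3-methylphenyl in place of 3-methoxyphenyl no number is obtained, and compound 4 joins the compounds that stop at the limit: the limit of > 100000 nM in this assay, at which 2 of the 4 values shown sit.

From the compounds shown here alone, how far compound 4 lies past that limit stays open, and so does whether the true step goes beyond the scatter. The compounds shown also leave open what an amine or a carboxylic acid in place of the methoxy group would give.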